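A few compounds are considered here, and "the series" means these few. Any claim that something is new, unique, unknown or untested is made for them only; others in the source may bear on it.

Measured in a functional assay on HT-29 cells (Homo sapiens) for inhibition, read by MTT assay, with a stated time of 48 h; on this read-out lower numbers stand for stronger inhibition and higher numbers for weaker inhibition:
- Compound 1 `COc1ccc(-n2c(SC)nnc2-c2cc(OC)c(OC)c(OC)c2)cc1`: > 60000 nM (a limit)
- Compound 2 `COc1ccc(-n2c(SCC(=O)C3CC3)nnc2-c2cc(OC)c(OC)c(OC)c2)cc1`: > 60000 nM (a limit)
- Compound 3 `COc1ccc(NC(=O)CSc2nnc(-c3cc(OC)c(OC)c(OC)c3)n2-c2ccc(OC)cc2)cc1`: 45300 nM

Compound 3 is the only one of these with an actual number, 45300 nM. The other values are not numbers, and the series stands at the limit of > 60000 nM in this assay, at which 2 of the 3 values shown sit. Two measured steps end at the compound with the number: an at least 1.3-fold lower number from compound 1 to compound 3 (0.12 log units; that floor lies within the scatter), and an at least 1.3-fold lower number from compound 2 to compound 3 (0.12 log units; that floor lies within the scatter). Both are only floors, and both floors lie within the scatter. The third is a step that the two limits leave unreadable from compound 1 to compound 2. All three steps concern the group on the sulfur chain, and none alters a substituent on the outer aromatic ring, so they set no size for the next change.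

Compound 4 `COc1ccc(-n2c(SCC(=O)Nc3ccc(Cl)cc3)nnc2-c2cc(OC)c(OC)c(OC)c2)cc1` differs from compound 3 in one place: chloro in place of methoxy on an aromatic carbon, para to a large group (chloro in place of methoxy on an aromatic carbon). Among the measured compounds shown here, with no measured precedent for this swap, no step beyond the scatter is expected in this assay, and neither direction is favoured. The expectation therefore stays anchored on compound 3 at 45300 nM. The expected step is a 1.1-fold lower number from compound 3 to compound 4 (0.05 log units; within the scatter). For compound 4 the estimate is 40000 nM, with an expected range from 12000 nM to 60000 nM.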

Compound 4, half-maximal inhibitory concentration: 58000 nM
Compound 4: the middle estimate sits 1.5-fold (0.16 log units) below what was measured, within the range that was stated.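

In this assay, the swap from (4-methoxyphenyl)carbamoyl to (4-chlorophenyl)carbamoyl is the only step shown that changes a substituent on the outer aromatic ring, and it gives a 1.3-fold higher number from compound 3 to compound 4 (0.11 log units; within the scatter), so methoxy and chloro at this position cannot be told apart in this read-out. Set against the two compounds that carry only a limit, the new compound gives an at least 1.0-fold lower number from compound 2 to compound 4 (0.01 log units; that floor lies within the scatter) and an at least 1.0-fold lower number from compound 1 to compound 4 (0.01 log units; that floor lies within the scatter); these are floors rather than measured sizes, so neither separates the (4-chlorophenyl)carbamoyl group from what stands on the sulfur chain in those compounds. Nothing in these steps moves the series clear of the limit of the assay: the limit of > 60000 nM in this assay, at which 2 of the 4 values shown sit.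

The compounds shown leave open whether a different group at this same position, such as an amine, a carboxylic acid or a trifluoromethyl group, would shift the number beyond the scatter. Also open, as far as these compounds go, is whether a change to the group on the sulfur, such as a longer chain, would bring a number well away from that limit.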